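This account rests on a few compounds, and the source may have more. Where it says the series, first, only, none or still open, it means among the compounds named here.

Measured so far in an assay on isolated protein for displacement of a labelled ligand from 5-hydroxytryptamine receptor 6 (Homo sapiens); a lower number here means a stronger inhibitor, a higher number a weaker inhibitor: compound 1 `COc1cccc(S(=O)(=O)c2ccc3c(c2)CCC[C@H]3CN)c1` gives 0.398 nM; compound 2 `CNC[C@@H]1CCCc2cc(S(=O)(=O)c3cc[nH]c3)ccc21` gives 0.159 nM; compound 3 `O=C1CN=C(NC[C@@H]2CCCc3cc(S(=O)(=O)c4cccc(F)c4)ccc32)N1` gives 0.1 nM.

Compound 3 holds the lowest of the three numbers, though compound 2 sits within the scatter of it, while compound 1 lies beyond the scatter. Compound 4 `CN(C[C@@H]1CCCc2cc(S(=O)(=O)c3cccc(F)c3)ccc21)C(N)=O` differs from compound 3 in one place: a group of 5 heavy atoms (2 carbon, 2 nitrogen, 1 oxygen; no ring) in place of a group of 7 heavy atoms (3 carbon, 3 nitrogen, 1 oxygen; one five-membered non-aromatic ring with 2 hetero atoms), on a saturated chain carbon bound to a saturated ring carbon. Within the data shown here, no measured pair shows this kind of change, so the direction rests on the change itself and on the values shown. In this assay a modest rise in the number is expected, and the expected step is a 5.0-fold higher number from compound 3 to compound 4 (0.70 log units; beyond the scatter). Compound 4 is thus estimated at 0.5 nM, within 0.15 nM to 2 nM.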

Compound 4, inhibition constant: 39.8 nM
Compound 4: the middle estimate sits 80-fold (1.90 log units) below what was measured, and the stated range ends below it.
By their numbers in this assay, from the lowest: compounds 3 and 2 (each within the scatter of the next); then compound 1; then compound 4.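

In this assay, putting carbamoyl(methyl)amino in place of the ring-bearing group of compound 3, on a saturated chain carbon bound to a saturated ring carbon, gives a 400-fold higher number from compound 3 to compound 4 (2.60 log units; beyond the scatter) and shows that this position is far from indifferent to what it carries. The earlier compounds shown here formed no pair that could reveal a change of this size at this place. Nothing given here explains the size of this step. Still open, as far as these compounds go, is whether an open-chain guanidine or an acetamide at this place would read close to compound 3 or close to compound 4.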